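Removing one methoxy from compound 2

The source may hold more compounds than are shown below. What is called first, only, known or untested is meant among the compounds shown, and "the series" means these compounds.

Values in an ADME assay on HEK-293T cells (Homo sapiens) for inhibition, read by CCK-8 assay, with a stated time of 48 h, tested at 20 uM (on this read-out lower numbers stand for less inhibition of growth and higher numbers for more inhibition of growth at the one concentration tested), for the measured compounds:
compound 1 `COc1ccc(Cc2nnc(NC(=O)/C(C#N)=C/c3ccccc3OS(=O)(=O)c3ccc(C)cc3)s2)cc1` gives 21%
compound 2 `COc1ccc(Cc2nnc(NC(=O)/C(C#N)=C/c3ccccc3OS(=O)(=O)c3ccc(OC)cc3)s2)cc1` gives 30%
compound 3 `COc1ccc(Cc2nnc(NC(=O)/C(C#N)=C/c3ccccc3OS(=O)(=O)c3ccccc3[N+](=O)[O-])s2)cc1` gives 18%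

Compound 2 stands clear of only one of the other two. Its step to compound 3 (a number 12 percentage points lower from compound 2 to compound 3 (beyond the scatter)) lies beyond the scatter, while its step from compound 1 (a number 9 percentage points higher from compound 1 to compound 2 (within the scatter)) does not.

Compound 4 `COc1ccc(S(=O)(=O)Oc2ccccc2/C=C(\C#N)C(=O)Nc2nnc(Cc3ccccc3)s2)cc1` has not yet been measured. It turns the 4-methoxybenzyl of compound 2 into benzyl, with hydrogen in place of methoxy on an aromatic carbon. For the measured compounds named here, no measured step touches this place, so the evidence is indirect. The three measured steps all lie at the sulfonyl end. Going by the values given here, these are the two above and one more (a number 3 percentage points lower from compound 1 to compound 3 (within the scatter)), and only the step to compound 3 from compound 2 exceeds the scatter, modestly. No step beyond the scatter is therefore expected in this assay for this change. The expected step (a number 4 percentage points lower from compound 2 to compound 4 (within the scatter)) is small. Compound 4 is expected at 26% with an estimated range of 14% to 38% on this read-out.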

Compound 4, percent growth inhibition at one concentration: 23%
Beside the measured number, compound 4's estimate is 3 percentage points above it; the measured number falls inside the stated range.
By their numbers in this assay, from the lowest: compounds 3, 1, 4 and 2 (each within the scatter of the next, the first and the last beyond it).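

In this assay, for the compounds shown here, the change from 4-methoxybenzyl to benzyl gives the first reading at this end of the molecule, since all earlier steps lay at the sulfonyl end: a number 7 percentage points lower from compound 2 to compound 4 (within the scatter). Compound 4 therefore cannot be told apart from compound 2, and this methoxy, para to a large group, is not shown to matter for this read-out at the one concentration tested. Nothing measured here bears on why this step stays so small.

The compounds shown leave open whether an amine or a carboxylic acid at this place would give a step beyond the scatter in this assay. They also leave open whether the same exchange of methoxy for hydrogen on the 4-methoxyphenyl at the sulfonyl end would read alike.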